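Amide series: replacing the bicyclic group on the aryl ring

A few compounds are considered here, and "the series" means these few. Any claim that something is new, unique, unknown or untested is made for them only; others in the source may bear on it.

Of the compounds shown here, three have been measured so far in an assay on HeLa cells for agonist activity at Bile acid receptor (Homo sapiens), read by a luciferase reporter, with a stated time of 24 h; on this read-out lower numbers stand for an effect already at smaller amounts and higher numbers for an effect only at larger amounts of compound. Compound 1 `CC(C)(C)c1ccc(C(=O)NCc2ccc(NS(=O)(=O)C3CC3)cc2Cl)cc1` gives 1500 nM. Compound 3 `CN(C)c1ccc(C(=O)NCc2ccc(NS(C)(=O)=O)cc2Cl)cc1` gives 1460 nM. Compound 2 `CS(=O)(=O)Nc1ccc(CNC(=O)c2ccc(C34CC(C3)C4)cc2)c(Cl)c1` gives 560 nM, the lowest of the three numbers; its nearest neighbour is compound 3, and the step of a 2.6-fold higher number from compound 2 to compound 3 (0.42 log units; beyond the scatter) is beyond the scatter, as is the gap to compound 1.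

Compound 4 `CS(=O)(=O)Nc1ccc(CNC(=O)c2ccc(N3CCCCC3)cc2)c(Cl)c1` is the next member. Relative to compound 2 the change is a group of 6 heavy atoms (5 carbon, 1 nitrogen; one six-membered non-aromatic ring with 1 hetero atom) in place of a group of 5 heavy atoms (5 carbon; 2 four-membered non-aromatic rings of carbon only), on an aromatic carbon. Among the measured compounds shown here, only one measured step bears on this position: in a 2.6-fold higher number from compound 2 to compound 3 (0.42 log units; beyond the scatter) the bicyclic carbon group of compound 2 was replaced by an acyclic amino group of compound 3 and the number rose modestly. Compound 4 also carries a nitrogen at that carbon, but within a six-membered ring of a size closer to the group it replaces, so a change of the same direction but smaller than from compound 2 to compound 3, or none beyond the scatter, is expected in this assay.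

The estimated step from compound 2 to compound 4 is therefore a 1.6-fold higher number from compound 2 to compound 4 (0.21 log units; within the scatter), and compound 4 is expected to give about 900 nM, within a range from 350 nM to 2300 nM.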

Compound 4, half-maximal effective concentration: 410 nM
For compound 4 the middle estimate is 2.2-fold (0.34 log units) above the measured one; the range from low to high includes it.
By their numbers in this assay, from the lowest: compounds 4 and 2 (each within the scatter of the next); then compounds 3 and 1 (each within the scatter of the next).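

In this assay, the step of a 1.4-fold lower number from compound 2 to compound 4 (0.14 log units; within the scatter) shows that piperidin-1-yl can take the place of the bicyclic carbon group on this aromatic carbon with no change beyond the scatter, so a nitrogen attached at this carbon does not by itself go with the higher number seen in a 2.6-fold higher number from compound 2 to compound 3 (0.42 log units; beyond the scatter). The step of a 3.6-fold lower number from compound 3 to compound 4 (0.55 log units; beyond the scatter) lies beyond the scatter even though both groups attach through nitrogen, which places the difference between dimethylamino and piperidin-1-yl in the rest of the group, its ring and its carbon count, rather than in the attaching atom. Nothing available here accounts for either step, and the three compounds alone give no reason for the difference.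

The compounds shown leave open whether the ring size matters, which pyrrolidin-1-yl or azepan-1-yl at this carbon would test, and whether a ring oxygen, as in morpholin-4-yl, is accepted in place of the far ring carbon. A cyclohexyl group would also show whether the ring nitrogen of piperidin-1-yl counts at all.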